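Diaryl-methyl sulfoxides on the dopamine transporter: notes

The source may hold more compounds than are shown below. What is called first, only, known or untested is meant among the compounds shown, and "the series" means these compounds.

Measured so far:
- compound 1 `Cc1nnc(C[S+]([O-])C(c2ccccc2)c2ccccc2)s1`: "not active" (no number reported)
- compound 2 `COc1ccnc(C[S+]([O-])C(c2ccccc2)c2ccccc2)c1OC`: "not active" (no number reported)
- compound 3 `Cc1ccc(C(c2ccc(C)cc2)[S+]([O-])Cc2cccs2)cc1`: 5800 nM

All three were run in an assay on HEK293 cells for inhibition of sodium-dependent dopamine transporter (Homo sapiens), read by scintillation counting, with stated times of 5 min and 1 min; on this read-out higher numbers stand for weaker inhibition and lower numbers for stronger inhibition. Compound 1 returns "not active" (no number reported) there, which is not a number but a statement that no inhibition was measured. Compound 2 returns the same outcome, "not active" (no number reported), again without a number. For the measured compounds named here, only compound 3 gives a value, 5800 nM, a weak result, and it carries a different core from compound 1 so no step between the two can be drawn.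

Compound 4 `[O-][S+](Cc1ccncc1)C(c1ccccc1)c1ccccc1` keeps the core of compound 1 and changes one group: pyridin-4-yl in place of 5-methyl-1,3,4-thiadiazol-2-yl on a saturated chain carbon bound to a sulfur. With compound 1 standing below measurable inhibition in this assay, the starting point has no number to step from. The expectation for compound 4 in this assay is a weak result, somewhere near what compound 3 shows, with a real chance that no number is obtained at all. Compound 4 is estimated at 8000 nM, within a range of 2000 nM to 40000 nM.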

Compound 4, half-maximal inhibitory concentration: 63500 nM
Compound 4: middle estimate off by 7.9-fold (0.90 log units), on the low side, and the stated range ends below it.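

For the compounds shown here, no step from compound 1 to compound 4 can be read: in this assay compound 1 gives "not active" (no number reported) and compound 4 gives 63500 nM as its value. The compounds shown leave open how far pyridin-4-yl in place of 5-methyl-1,3,4-thiadiazol-2-yl shifts inhibition. No supporting data bear on this result.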